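Swapping an isoquinoline amide for a cinnamamide on a dodecyl threonine amide

This account rests on a few compounds, and the source may have more. Where it says the series, first, only, none or still open, it means among the compounds named here.

Compounds measured in a functional assay on HepG2 cells (Homo sapiens) for cytotoxicity, read by MTT assay, with a stated time of 48 h; on this read-out lower numbers stand for stronger inhibition and higher numbers for weaker inhibition:
Compound 1 `CCCCCCCCNC(=O)[C@@H](NC(=O)/C=C/c1ccccc1)[C@@H](C)O` gives 55600 nM.
Compound 2 `CCCCCCCCCCCCNC(=O)[C@@H](NC(=O)c1cc2ccccc2o1)[C@@H](C)O` gives 22900 nM.
Compound 3 `CCCCCCCCCCCCNC(=O)[C@@H](NC(=O)c1nccc2ccccc12)[C@@H](C)O` gives 65700 nM.

Among these three, compound 3 holds the highest number in this assay. Its value and that of compound 1 sit within the usual scatter of each other, so no order can be read between them, while compound 2 lies clearly lower.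

Compound 4 `CCCCCCCCCCCCNC(=O)[C@@H](NC(=O)/C=C/c1ccccc1)[C@@H](C)O` is compound 3 with one change: 2-phenylethenyl in place of isoquinolin-1-yl on a carbonyl carbon. For the measured compounds named here, only one measured step bears on this part of the molecule: a 2.9-fold higher number from compound 2 to compound 3 (0.46 log units; beyond the scatter), which shows that exchanging the aromatic group on that carbonyl carbon can move the number by a modest amount. Compound 1 already carries the 2-phenylethenyl group, though on a shorter chain, and its number sits close to that of compound 3. Taken together, a small step downward is expected in this assay, perhaps not beyond the scatter: the change from compound 3 to compound 4 is estimated as a 1.5-fold lower number from compound 3 to compound 4 (0.16 log units; within the scatter). Compound 4 is therefore expected at 45000 nM, within a range of 20000 nM to 100000 nM.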

Compound 4, half-maximal inhibitory concentration: > 200000 nM
Compound 4: no number, only a limit (the forecaster's own chance of this, stated with the estimate: 10%); middle value at least 4.4-fold (0.64 log units) away from the limit.
By their numbers in this assay, from the lowest: compound 2; then compounds 1 and 3 (each within the scatter of the next). At a limit, above all of these: compound 4.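

In this assay, compound 4 has no number, only a limit of the assay: the limit of > 200000 nM in this assay, at which 1 of the 4 values shown sits. Even so, the group on the carbonyl carbon is shown to matter on the dodecyl chain: 2-phenylethenyl gives an at least 3.0-fold higher number from compound 3 to compound 4 (0.48 log units; beyond the scatter) and an at least 8.7-fold higher number from compound 2 to compound 4 (0.94 log units; beyond the scatter), and the second step is larger than any step seen among the earlier compounds. For the compounds shown here, the chain matters too, which the earlier compounds could not show for a single carbonyl group: with 2-phenylethenyl held fixed, the added butyl gives an at least 3.5-fold higher number from compound 1 to compound 4 (0.55 log units; beyond the scatter).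

The compounds shown leave open whether the same chain change would move the number in the same direction with 1-benzofuran-2-yl or isoquinolin-1-yl on the carbonyl carbon. They also leave open how a longer chain, or an amine on the 2-phenylethenyl group, would read in this assay.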